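Working notes on a small series of glycosides

A few compounds are considered here, and "the series" means these few. Any claim that something is new, unique, unknown or untested is made for them only; others in the source may bear on it.

Measured so far:
compound 1, `COc1cc([C@H]2c3cc(O)c(OC)cc3C[C@@H](CO)[C@@H]2CO[C@@H]2O[C@@H](C)[C@H](O)[C@@H](O)[C@H]2O)ccc1O`: 40200 nM
compound 2, `COc1cc(C[C@H]2CO[C@@H](c3cc(OC)c(O)c(OC)c3)[C@H]2CO[C@@H]2O[C@@H](C)[C@H](O)[C@@H](O)[C@H]2O)cc(OC)c1O`: 29800 nM
compound 3, `COc1cc(C[C@H](CO)[C@@H](CO[C@@H]2O[C@@H](C)[C@H](O)[C@@H](O)[C@H]2O)Cc2cc(OC)c(O)c(OC)c2)cc(OC)c1O`: 21300 nM

All three numbers come from a functional assay on BV-2 cells (Mus musculus) for inhibition, read by Griess assay, with stated times of 30 min and 24 h; on this read-out higher numbers stand for weaker inhibition and lower numbers for stronger inhibition. Compound 2 stands second highest of the three; its nearest neighbour is compound 1, whose number is higher by an amount within the scatter, and the furthest is compound 3, whose number is lower by an amount that is also within the scatter. Among the compounds with values here, no pair of measured compounds differs in a single place, so the three numbers are read as one cluster of weak inhibitors rather than as any trend.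

Compound 4, `COc1cc(C[C@@H]2CO[C@@H](c3cc(OC)c(O)c(OC)c3)[C@@H]2CO[C@@H]2O[C@@H](C)[C@H](O)[C@@H](O)[C@H]2O)cc(OC)c1O`, has not yet been measured in this assay. It differs from compound 2 as follows: the two compounds have the same atoms and bonds and differ only in configuration as drawn: 2 of 8 stereo elements differ; a stereocentre at a saturated ring carbon is drawn R in compound 2 and S in compound 4; a stereocentre at a saturated ring carbon is drawn R in compound 2 and S in compound 4. No measured pair in the series isolates a change of configuration, so there is no shown step to lean on; the expectation rests only on the narrow spread across compound 1, compound 2 and compound 3. The expected step is a 1.0-fold higher number from compound 2 to compound 4 (0.00 log units; within the scatter), meaning none beyond the scatter, with room for a move in either direction kept in the range. Compound 4 is therefore estimated at 30000 nM, within 10000 nM to 90000 nM.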

Compound 4, half-maximal inhibitory concentration: 199000 nM
Beside the measured number, compound 4's estimate is 6.6-fold (0.82 log units) below it, and the stated range ends below it.
By their numbers in this assay, from the lowest: compounds 3, 2 and 1 (each within the scatter of the next); then compound 4.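

In this assay, changing two saturated ring carbons from R as drawn in compound 2 to S in compound 4 gives a 6.7-fold higher number from compound 2 to compound 4 (0.82 log units; beyond the scatter), a clear loss of inhibition with no change in atoms or bonds. Within the data shown here, this is the only step that can be read, and it shows what the cluster of earlier numbers could not: on this read-out, the configuration at these two stereocentres matters, with the R,R arrangement of compound 2 giving the stronger inhibition of the pair. The step can be assigned to configuration alone, and not to any change of substituent, because nothing else separates the pair: the fact that compounds 2 and 4 differ only in the configuration as drawn

Both stereocentres change together, so the compounds shown leave open whether one of them carries the step or both are needed, and whether changing either alone would give a step of a similar size. Also open, as far as these compounds go, is whether the same dependence on configuration would hold with a carboxylic acid or an amine on the shared core, or on the cores of compound 1 and compound 3.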